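This account rests on a few compounds, and the source may have more. Where it says the series, first, only, none or still open, it means among the compounds named here.

Compound 1 `O=C(O)CCCSCCN1C(=O)OC[C@@H]1/C=C/[C@@H](O)Cc1ccccc1` gives the higher of the two measured numbers in a functional assay on CHO cells for agonist activity at prostaglandin E2 receptor EP4 subtype (Rattus norvegicus), read by cAMP accumulation and immunoassay, with a stated time of 10 min (on this read-out lower numbers stand for an effect already at smaller amounts and higher numbers for an effect only at larger amounts of compound), where compound 1 gives 36 nM. Compound 2 `Cc1cccc(C[C@H](O)/C=C/[C@H]2CCC(=S)N2CCSCCCC(=O)O)c1` in this assay gives 7.7 nM, a clearly lower number than that of compound 1. Compound 3 `COCc1cccc(C[C@H](O)/C=C/[C@H]2COC(=O)N2CCSCCCC(=O)O)c1` has not yet been measured in this assay. Compared with compound 1, the only change is methoxymethyl in place of hydrogen on an aromatic carbon. Among the measured compounds shown here, no measured pair shows this change alone, so its effect is open; still, a moderate step toward a lower number is expected, a 2.4-fold lower number from compound 1 to compound 3 (0.38 log units; beyond the scatter). For compound 3 the expected value is 15 nM, with a range from 4 nM to 60 nM.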

Compound 3, half-maximal effective concentration: 24 nM
Beside the measured number, compound 3's estimate is 1.6-fold (0.20 log units) below it, and the stated range covers the measured number.
By their numbers in this assay, from the lowest: compound 2; then compounds 3 and 1 (each within the scatter of the next).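

Methoxymethyl in place of hydrogen on an aromatic carbon gives a 1.5-fold lower number from compound 1 to compound 3 (0.18 log units; within the scatter) in this assay. Among the compounds shown here, this position therefore takes a group of this size without moving the number outside the scatter, something the earlier compounds could not show. No measurement at hand gives a reason for this result.

On these data alone, whether an amine or a carboxylic acid at this same place would move the number beyond the scatter remains open. So does whether methoxymethyl would behave alike on the other carbons of this ring.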